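Pyridyl for tolyl on the oxadiazole: a within-scatter swap

The source may hold more compounds than are shown below. What is called first, only, known or untested is meant among the compounds shown, and "the series" means these compounds.

Measured compounds in a functional assay on HCT-116 cells (Homo sapiens) for inhibition, read by MTT assay, with a stated time of 24 h, tested at 10 uM; on this read-out higher numbers stand for more inhibition of growth at the one concentration tested and lower numbers for less inhibition of growth:
Compound 1 `CS(=O)(=O)c1ccc(-c2cnc3[nH]cc(-c4nnc(-c5ccccn5)o4)c(=O)c3c2)cc1`: 16.2%
Compound 2 `Cc1ccc(-c2nnc(-c3c[nH]c4ncc(-c5ccc(S(C)(=O)=O)cc5)cc4c3=O)o2)cc1`: 24.4%

Among the compounds with values here, compound 2 gives the higher of the two numbers in this assay, but its only neighbour is compound 1, and the step of a number 8.2 percentage points higher from compound 1 to compound 2 (within the scatter) does not exceed the scatter, so the two values cannot be ordered with confidence.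

Compound 3 `CS(=O)(=O)c1ccc(-c2cnc3[nH]cc(-c4nnc(-c5cccnc5)o4)c(=O)c3c2)cc1` is the unmeasured member of the set. Its change from compound 2 is pyridin-3-yl in place of 4-methylphenyl on an aromatic carbon. Within the data shown here, only one measured step bears on this change: a number 8.2 percentage points higher from compound 1 to compound 2 (within the scatter), in which a pyridyl group gave way to 4-methylphenyl without a difference beyond the scatter. The change to compound 3 runs the other way, from 4-methylphenyl to a pyridyl group, here pyridin-3-yl rather than pyridin-2-yl. On that single step no movement beyond the scatter is expected, perhaps a slight drift back toward the number of compound 1. The step expected here is a number 6.4 percentage points lower from compound 2 to compound 3 (within the scatter), which stays within the scatter. Compound 3 is therefore estimated at 18%, with a range from 5% to 33%.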

Compound 3, percent growth inhibition at one concentration: 14.7%
The estimate for compound 3 lay 3.3 percentage points above the measured number; low and high end bracket the measured number.
By their numbers in this assay, from the lowest: compounds 3, 1 and 2 (each within the scatter of the next).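

In this assay, pyridin-3-yl in place of 4-methylphenyl on this aromatic carbon gives a number 9.7 percentage points lower from compound 2 to compound 3 (within the scatter) and so joins pyridin-2-yl as a second pyridyl group that does not separate from 4-methylphenyl beyond the scatter. Moving the ring nitrogen of the pyridyl group also leaves no readable difference: pyridin-3-yl in place of pyridin-2-yl gives a number 1.5 percentage points lower from compound 1 to compound 3 (within the scatter), so the three groups tried at this carbon, all six-membered aromatic rings, cannot be ordered on this read-out. Nothing at hand explains why the three values lie so close together.

The compounds shown leave open whether any group on this carbon of the five-membered ring can move the number beyond the scatter; all three carry a six-membered aromatic ring there, and an amine such as morpholine, a carboxylic acid or a longer alkyl chain would put a different kind of group in its place. Also open, going by these compounds, is whether the same lack of separation would hold with the other parts of the shared core changed, since only this one place varies here.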